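The source may report more compounds than this note shows. Statements on the series, on what has been measured and on what is new or still open speak of the compounds shown alone.

Compound 1 `Cc1ccccc1C(=O)NCc1ccc(CNS(=O)(=O)c2ccccc2C)cc1` gives 10 nM in an assay on MDA-MB-231 cells for displacement of a labelled ligand from C-X-C chemokine receptor type 4 (Homo sapiens), read by fluorescence and microscopy, with stated times of 10 min and 30 min; on this read-out higher numbers stand for an effect only at larger amounts of compound and lower numbers for an effect already at smaller amounts.
Compound 2 `Cc1ccccc1C(=O)NCc1ccc(CNS(=O)(=O)c2ccc(F)cc2)cc1` gives 10 nM in this assay.
Compound 3 `Cc1cccc(S(=O)(=O)NCc2ccc(CNC(=O)c3ccccc3C)cc2)c1` gives 1000 nM in this assay.

Compound 3 stands highest of the three numbers: it is separated from compound 1 by a 100-fold higher number from compound 1 to compound 3 (2.00 log units; beyond the scatter) and from compound 2 by a 100-fold higher number from compound 2 to compound 3 (2.00 log units; beyond the scatter), while no change at the digits printed from compound 1 to compound 2 (within the scatter). Compound 4 `Cc1ccccc1C(=O)NCc1ccc(CNS(=O)(=O)c2cccc(Cl)c2)cc1` differs from compound 3 by chloro in place of methyl on an aromatic carbon. Within the data shown here, no measured step exchanges chloro for methyl at this place; the two large steps turn on where the group sits rather than on which group it is, and the one exchange of groups between different places stayed within the scatter. Compound 4 in this assay is therefore expected to show a 1.4-fold lower number from compound 3 to compound 4 (0.15 log units; within the scatter), not beyond the scatter. Compound 4 is estimated at 700 nM, between 150 nM and 3000 nM.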

Compound 4, effective concentration (reported as EC, without a stated level of effect): 100 nM
Compound 4: the middle estimate sits 7.0-fold (0.85 log units) above what was measured; the whole stated range lies above it.
By their numbers in this assay, from the lowest: compounds 1 and 2 (each within the scatter of the next); then compound 4; then compound 3.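

At this place, meta to a large group, the choice of group matters as well as its position: chloro in place of methyl gives a 10-fold lower number from compound 3 to compound 4 (1.00 log units; beyond the scatter) in this assay. The 3-chlorophenyl group still does not match the other two sulfonyl substituents, with a 10-fold higher number from compound 2 to compound 4 (1.00 log units; beyond the scatter) and a 10-fold higher number from compound 1 to compound 4 (1.00 log units; beyond the scatter). Nothing at hand explains why chloro and methyl differ here.

Going by these compounds, what a nitrile, an amine or a carboxylic acid would give at this place remains open. So does the effect of chloro elsewhere on this ring.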